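Shortening the terpene chain of an acylguanidine

A few compounds are considered here, and "the series" means these few. Any claim that something is new, unique, unknown or untested is made for them only; others in the source may bear on it.

The set comprises three acylguanidines that have been measured, together with one that has not. Compound 1 `CC(C)=CC(=O)NC(=N)NC(=O)C=C(C)C` carries two short unsaturated acyl groups on the guanidine, compound 3 `C=C1CCCC(C)(C)[C@@H]1CC/C(C)=C/C(=O)NC(=N)NC(=O)C=C(C)C` pairs one of them with a longer chain bearing a ring, and compound 2 `CC(C)=CCC/C(C)=C/CC/C(C)=C/C(=O)NC(=N)N` has a single long unsaturated chain on a free guanidine. In a functional assay on A549 cells (Homo sapiens) for inhibition, read by MTT assay, with a stated time of 72 h (on this read-out lower numbers stand for stronger inhibition of growth and higher numbers for weaker inhibition of growth), compound 1 gives 75600 nM, compound 3 gives 29400 nM, and compound 2 gives 13700 nM, the lowest of the three numbers, with compound 3 nearest and compound 1 furthest, both beyond the scatter.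

Compound 4 `CC(C)=CCC/C(C)=C/C(=O)NC(=N)N` is the unmeasured member. It differs from compound 2 in one place: hydrogen in place of 3-methylbut-2-en-1-yl on a saturated chain carbon bound to a double-bonded chain carbon. Among the measured compounds shown here, no measured pair shows this change, so its size can only be guessed from the spread among compounds 1, 2 and 3. The expectation is for weaker growth inhibition, with a step from compound 2 to compound 4 of a 2.6-fold higher number from compound 2 to compound 4 (0.41 log units; beyond the scatter) in this assay. Compound 4 is accordingly estimated at 35000 nM, within a range from 12000 nM to 100000 nM.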

Compound 4, concentration for 50% growth inhibition: 76500 nM
Estimate against measurement, compound 4: 2.2-fold (0.34 log units) below, within the range that was stated.
By their numbers in this assay, from the lowest: compound 2; then compound 3; then compounds 1 and 4 (each within the scatter of the next).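

In this assay, among the compounds shown here, placing hydrogen where the 3-methylbut-2-en-1-yl stood, on a saturated chain carbon bound to a double-bonded chain carbon, gives a 5.6-fold higher number from compound 2 to compound 4 (0.75 log units; beyond the scatter), the first step in this set between compounds that differ in one place. With the rest of the structure unchanged, this place on the chain is thus not indifferent: in this pair, the 3-methylbut-2-en-1-yl goes with stronger inhibition of growth than hydrogen. Nothing measured here explains the size of this step.

This single pair cannot tell whether the step follows the chain's length or its double bond, which a saturated 3-methylbutyl in the same place would help to separate. As far as these compounds go, whether an amine or a carboxylic acid could stand there also remains open, as does whether a longer chain would go further.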